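A few compounds are considered here, and "the series" means these few. Any claim that something is new, unique, unknown or untested is made for them only; others in the source may bear on it.

Measured so far:
- compound 1, `Cc1ccc(-c2nc(=O)o[nH]2)c(-c2ccc([C@@H](C)N(CC3CC3)c3nc4c(C(=O)O)cccc4o3)cc2)c1`, in a functional assay on CAL1 cells for inhibition of chemerin-like receptor 1 (Homo sapiens), with a stated time of 45 min (a lower number here means a stronger inhibitor, a higher number a weaker inhibitor), compound 1 gives 3.2 nM
- compound 2, `CCCCN(c1nc2c(C(=O)NC)cccc2o1)[C@H](C)c1ccc(-c2ccccc2-c2nnn[nH]2)cc1`, in this assay compound 2 gives 110 nM

Of the two numbers in this assay, compound 2 gives the higher one, so it is the weaker inhibitor of the pair, and the gap to compound 1 is beyond the usual scatter of repeated measurements.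

Compound 3, `CCCCN(c1nc2c(C(=O)O)cccc2o1)[C@H](C)c1ccc(-c2ccccc2-c2nnn[nH]2)cc1`, has not been measured yet. It differs from compound 2 in one place: hydroxy in place of methylamino on a carbonyl carbon. Within the data shown here, compound 1, the stronger inhibitor, carries a carboxy group in the same position, though it also differs from compound 2 elsewhere, so no single step between measured compounds isolates this change.

In this assay the step from compound 2 to compound 3 is expected to be a drop of a 3.7-fold lower number from compound 2 to compound 3 (0.56 log units; beyond the scatter), beyond the scatter. For compound 3 in this assay the estimate is 30 nM, expected to fall between 8 nM and 120 nM.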

Compound 3, half-maximal inhibitory concentration: 17 nM
Estimate against measurement, compound 3: 1.8-fold (0.25 log units) above; low and high end bracket the measured number.
By their numbers in this assay, from the lowest: compound 1; then compound 3; then compound 2.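

In this assay, replacing methylamino with hydroxy on a carbonyl carbon, which turns methylcarbamoyl into carboxy, gives a 6.5-fold lower number from compound 2 to compound 3 (0.81 log units; beyond the scatter). Compound 2 and compound 3 differ in this one place alone, so this step shows the effect of this change by itself, which the two earlier compounds, differing in more than one place, could not do. The group that leaves and the group that enters both count one hydrogen-bond donor and no net charge, so those counts do not separate them, and nothing shown gives a measured reason for the step.

From the compounds shown here alone, it remains open how other groups on this carbonyl carbon, such as methoxy or dimethylamino, would compare with hydroxy and methylamino. Going by these compounds, it is also open whether the same change gives a step of similar size on the core of compound 1.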